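Replacing Trifluoromethoxy with Methoxy on a Shared Core

A few compounds are considered here, and "the series" means these few. Any claim that something is new, unique, unknown or untested is made for them only; others in the source may bear on it.

In a functional assay on SiHa cells (Homo sapiens) for inhibition, read by sulforhodamine B assay (a lower number here means a stronger inhibitor of growth, a higher number a weaker inhibitor of growth), compound 1 (`Oc1cccc2[nH]c(-c3ccc(-c4ccc(-c5ccc(C(F)(F)F)cc5)cc4)cc3)nc12`) gives 3720 nM, while compound 2 (`Oc1cccc2[nH]c(-c3ccc(-c4ccc(-c5ccc(OC(F)(F)F)cc5)cc4)cc3)nc12`) gives 8410 nM. Compound 2 therefore holds the higher of the two numbers and is the weaker inhibitor of growth of this pair. Compound 3 (`COc1ccc(-c2ccc(-c3ccc(-c4nc5c(O)cccc5[nH]4)cc3)cc2)cc1`) keeps the core of compound 2 but carries methyl in place of trifluoromethyl on an oxygen on an aromatic ring, so that trifluoromethoxy becomes methoxy: methyl in place of trifluoromethyl on an oxygen on an aromatic ring.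

For the measured compounds named here, only one measured step bears on this change: a 2.3-fold higher number from compound 1 to compound 2 (0.35 log units; beyond the scatter). That modest step came from trifluoromethoxy in place of trifluoromethyl on an aromatic carbon. Going by the values given here, it is a different exchange, and no measured compound carries methoxy, so it offers a rough scale for the change but does not settle its direction. A step of similar or smaller size is therefore expected in this assay, tentatively toward a lower number. The expected change is a 1.4-fold lower number from compound 2 to compound 3 (0.15 log units; within the scatter), which would stay within the scatter. For compound 3, the estimated value is 6000 nM, with an expected range from 2500 nM to 15000 nM.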

Compound 3, concentration for 50% growth inhibition: 4800 nM
The estimate for compound 3 lay 1.3-fold (0.10 log units) above the measured number, within the range that was stated.
By their numbers in this assay, from the lowest: compounds 1, 3 and 2 (each within the scatter of the next, the first and the last beyond it).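

In this assay, putting methyl in place of trifluoromethyl on an oxygen on an aromatic ring gives a step that stays within the scatter (a 1.8-fold lower number from compound 2 to compound 3 (0.24 log units; within the scatter)), so this first comparison of the two groups at this oxygen does not separate methoxy from trifluoromethoxy. The step that links compound 3 to the trifluoromethyl analogue also stays within the scatter (a 1.3-fold higher number from compound 1 to compound 3 (0.11 log units; within the scatter)), even though the two fluorinated compounds stand apart beyond it (a 2.3-fold higher number from compound 1 to compound 2 (0.35 log units; beyond the scatter)), which places methoxy within reach of both and gives the three end groups no clear order. The compounds offer no measurement that explains any of these numbers.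

As far as these compounds go, what remains open is whether a group of another kind at this end of the molecule, such as an amine, a carboxylic acid or a longer chain like ethoxy or butoxy, would give a step beyond the scatter from compound 3. Also open, from the compounds shown here alone, is whether the closeness of compound 2 and compound 3 holds on any other cell line, since all three numbers here come from a single assay on the shared core.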